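Ring methyl on compound 2: expected half-life

This account rests on a few compounds, and the source may have more. Where it says the series, first, only, none or still open, it means among the compounds named here.

In an ADME assay on the whole organism (strain Wistar Han) for metabolic stability, with Rattus norvegicus as the target, read by LC-MS, at a dose of 5 mg/kg by the oral route (on this read-out lower numbers stand for a shorter-lived compound and higher numbers for a longer-lived compound), compound 2 (`N#Cc1ccc(C(O)(C2CC2)C(F)(F)F)cc1C(F)(F)F`) gives 20 h. Compound 3 (`N#Cc1ccc(C(O)(C2CC2)C(F)(F)F)cc1Cl`) gives 18 h, within the scatter of compound 2. Compound 1 (`CCC(O)(c1ccc(C#N)c(C(F)(F)F)c1)C(F)(F)F`) gives 83 h. Compound 2 therefore stands level with compound 3 and clearly under compound 1.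

Compound 4 (`Cc1c(C(O)(C2CC2)C(F)(F)F)ccc(C#N)c1C(F)(F)F`) carries a single change from compound 2: methyl in place of hydrogen on an aromatic carbon. This is methyl in place of hydrogen on an aromatic carbon, ortho to a trifluoromethyl group and meta to a cyano group. Within the data shown here, no measured step adds a group at that carbon, so the evidence is indirect.

Among the measured compounds shown here, the only step beyond the scatter is a 4.2-fold lower number from compound 1 to compound 2 (0.62 log units; beyond the scatter). It swaps ethyl for cyclopropyl on a saturated chain carbon, so it bears little on an aromatic change. The nearer precedent is a 1.1-fold lower number from compound 2 to compound 3 (0.05 log units; within the scatter), with chloro in place of trifluoromethyl on an aromatic carbon. That single step stays within the scatter, so no step beyond the scatter is expected in this assay, and the data favour no direction.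

The estimated change is a 1.1-fold lower number from compound 2 to compound 4 (0.05 log units; within the scatter). Compound 4 is estimated at 18 h, with an expected range of 7 h to 45 h.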

Compound 4, half-life: 10 h
Estimate against measurement, compound 4: 1.8-fold (0.26 log units) above, and the stated range covers the measured number.
By their numbers in this assay, from the lowest: compounds 4, 3 and 2 (each within the scatter of the next); then compound 1.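

In this assay, methyl in place of hydrogen on this aromatic carbon, ortho to a trifluoromethyl group and meta to a cyano group, gives a 2.0-fold lower number from compound 2 to compound 4 (0.30 log units; within the scatter). Among these compounds, the earlier steps changed only the saturated chain carbon and the aromatic carbon bearing trifluoromethyl, so this is the first reading at this carbon, and it shows that a methyl can enter there without a step beyond the scatter. No supporting measurement bears on what lies behind this number.

On these data alone, a single small group at one carbon says little about larger or different groups there, so it remains open whether an ethyl chain, a methoxy group, an amine or a carboxylic acid at the same carbon would also stay within the scatter of compound 2. It also remains open whether the methyl would read the same way on the ethyl-bearing scaffold of compound 1 , which gives 83 h, since the compounds shown pair this ring change only with the cyclopropyl group.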